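The source may hold more compounds than are shown below. What is called first, only, known or untested is meant among the compounds shown, and "the series" means these compounds.

Measured so far in an assay on isolated protein for inhibition of leukotriene B4 receptor 1 (Homo sapiens), tested at 10 uM; a lower number here means less inhibition, a higher number more inhibition at the concentration tested (going by the name of the read-out):
- compound 1 `C=CCc1cc(C(C)=O)c(O)cc1OCCCC`: 32%
- compound 2 `C=CCc1cc(C(C)=O)c(O)cc1OCCCCCC(C)=O`: 98%

Compound 2 stands highest of the two numbers; compound 1 lies below it by the step of a number 66 percentage points higher from compound 1 to compound 2 (beyond the scatter). Compound 3 `C=CCc1cc(C(C)=O)c(O)cc1OCCCCCC(=O)OC` differs from compound 2 by methoxy in place of methyl on a carbonyl carbon. Within the data shown here, no measured step covers this change: the only step known, a number 66 percentage points higher from compound 1 to compound 2 (beyond the scatter), concerns the addition of the 2-oxopropyl group, not the exchange on its carbonyl carbon. Compound 2 already lies near the top of the read-out, so the expected step of a number 13 percentage points lower from compound 2 to compound 3 (beyond the scatter) is modest and downward. Compound 3 is therefore estimated at 85%, within 60% to 100%.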

Compound 3, a percentage reported as inhibition, at one concentration (the size of the read-out at that concentration, not a potency): 106%
Estimate against measurement, compound 3: 21 percentage points below, and the stated range ends below it.
By their numbers in this assay, from the lowest: compound 1; then compounds 2 and 3 (each within the scatter of the next).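

In this assay methoxy in place of methyl on the carbonyl carbon gives a number 8 percentage points higher from compound 2 to compound 3 (within the scatter) and does not separate the two compounds. The large gain over compound 1 is not tied to the 2-oxopropyl group alone: (methoxycarbonyl)methyl at the same place gives a number 74 percentage points higher from compound 1 to compound 3 (beyond the scatter) as well. Nothing available explains why the two groups read alike.

Compound 2 and compound 3 both sit at the top of a read-out taken at one concentration, so any difference in potency stays unresolved. Still open, on these data alone, is whether a carboxylic acid or an amide on that carbonyl carbon, or a longer chain, holds this level.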